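The source may report more compounds than this note shows. Statements on the series, on what has been measured and on what is new or still open speak of the compounds shown alone.

Working notes on the series. Compound 1 `O=C(NCCCCc1ccccc1)c1cccc(C2SCC(=O)N2c2cccc(-c3c[nH]nn3)c2)c1` gives 742 mL.min-1.g-1 in an ADME assay on microsomes from liver (Rattus norvegicus) for metabolic stability, read by LC-MS, using NADPH, with a stated time of 10 min, tested at 0.1 uM (a lower number here means slower removal, a higher number faster removal of the compound), the lowest of the two numbers at hand. Compound 2 `COc1ccccc1N1C(=O)C(C)SC1c1cccc(C(=O)NCCCCc2ccccc2)c1` gives 2910 mL.min-1.g-1 in this assay, a number that stands beyond the scatter above that of compound 1; the two compounds differ in more than one place, so only the two values themselves are noted here. Compound 3 `O=C(NCCCCc1ccccc1)c1cccc(C2SCC(=O)N2c2cccc(F)c2)c1` has not yet been measured in this assay. Against compound 1 it differs as follows: fluoro in place of 1H-1,2,3-triazol-4-yl on an aromatic carbon. Going by the values given here, no measured pair covers this change, so the step has to be estimated from the two values alone. The step from compound 1 to compound 3 is expected to raise the number by a moderate amount, a 2.0-fold higher number from compound 1 to compound 3 (0.31 log units; beyond the scatter), likely beyond the scatter. For compound 3 the estimated value in this assay is 1500 mL.min-1.g-1, with a range from 600 mL.min-1.g-1 to 3500 mL.min-1.g-1.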

Compound 3, intrinsic clearance in microsomes: 3240 mL.min-1.g-1
The estimate for compound 3 lay 2.2-fold (0.33 log units) below the measured number; measured number inside the range.
By their numbers in this assay, from the lowest: compound 1; then compounds 2 and 3 (each within the scatter of the next).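

Replacing 1H-1,2,3-triazol-4-yl with fluoro on this aromatic carbon, meta to a large group, gives in this assay a 4.4-fold higher number from compound 1 to compound 3 (0.64 log units; beyond the scatter). Going by these compounds alone, this is the first single-place reading, and it shows that the group at this position alone can move the number beyond the scatter, with the rest of compound 1 unchanged. No measurement at hand explains the step.

The compounds shown leave open whether the lower number of compound 1 is specific to the 1H-1,2,3-triazol-4-yl or would also be seen with another group at this carbon, such as a carboxylic acid, an amine or a plain hydrogen. They also leave open whether the same change would give a step of similar size on a differently substituted core.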